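Thiophen-2-yl in place of 4-fluorophenyl: working notes

This account rests on a few compounds, and the source may have more. Where it says the series, first, only, none or still open, it means among the compounds named here.

Measured in a functional assay on HL-60 cells (Homo sapiens) for cytotoxicity, read by CellTiter-Blue, with a stated time of 48 h (on this read-out higher numbers stand for weaker inhibition and lower numbers for stronger inhibition), so far:
- Compound 1 `COc1cc(OC)cc(-c2ccc3c(c2)C(CC(=O)OCC2CC2)C(C(=O)OCC2CC2)=C(N)O3)c1` gives 6700 nM
- Compound 2 `CCOC(=O)CC1C(C(=O)OCC)=C(N)Oc2ccc(-c3cccc(F)c3)cc21` gives 76400 nM
- Compound 3 `CCOC(=O)CC1C(C(=O)OCC)=C(N)Oc2ccc(-c3ccc(F)cc3)cc21` gives 72100 nM

Compound 3 stands level with compound 2 within the scatter and well above compound 1 on these numbers. Compound 4 `CCOC(=O)CC1C(C(=O)OCC)=C(N)Oc2ccc(-c3cccs3)cc21` carries thiophen-2-yl in place of 4-fluorophenyl on an aromatic carbon and is otherwise unchanged. For the measured compounds named here, the one measured step of a 1.1-fold lower number from compound 2 to compound 3 (0.03 log units; within the scatter) lies within the scatter, but it only exchanges one fluorophenyl group for another and so bears loosely on this ring exchange. No step beyond the scatter is expected in this assay and no direction is favoured. The expected step is a 1.2-fold lower number from compound 3 to compound 4 (0.08 log units; within the scatter) and it stays within the scatter. Compound 4 is estimated at 60000 nM with a range from 25000 nM to 130000 nM expected.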

Compound 4, half-maximal inhibitory concentration: > 80000 nM
Compound 4 gave a limit, no number; the forecaster's own chance of this, stated with the estimate: 10%; middle value at least 1.3-fold (0.12 log units) from the limit.
By their numbers in this assay, from the lowest: compound 1; then compounds 3 and 2 (each within the scatter of the next). At a limit, above all of these: compound 4.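

In this assay compound 4 gave a limit and not a number: the limit of > 80000 nM in this assay, at which 1 of the 4 values shown sits. From the compounds shown here alone, the steps can be read only as floors, an at least 1.1-fold higher number from compound 3 to compound 4 (0.04 log units; that floor lies within the scatter) and an at least 1.0-fold higher number from compound 2 to compound 4 (0.01 log units; that floor lies within the scatter), so their true size stays unknown. Thiophen-2-yl, a five-membered aromatic ring, is thus tolerated no better at this position than either fluorophenyl group, with no lower number than compound 2 or compound 3.

Open, going by these compounds, is whether an amine or a carboxylic acid on the aromatic ring here would move the number. Compound 1 differs from the others in more than one place, so its lower value cannot be tied to any single change.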